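Swapping 4-hydroxyphenyl for 2,6-dimethoxyphenyl on a shared core

The source may hold more compounds than are shown below. What is called first, only, known or untested is meant among the compounds shown, and "the series" means these compounds.

In a functional assay on MDA-MB-231 cells (Homo sapiens) for inhibition, read by sulforhodamine B assay, with a stated time of 48 h (a lower number here means a stronger inhibitor of growth, a higher number a weaker inhibitor of growth), compound 1 `O=C(Cc1csc2nc(-c3ccc(Br)cc3)cn12)N/N=C/c1ccccc1`, which has a plain phenyl ring on the carbon with a double bond to nitrogen, gives 12900 nM. Adding a hydroxy group to that ring gives compound 2 `O=C(Cc1csc2nc(-c3ccc(Br)cc3)cn12)N/N=C/c1ccccc1O` at 3240 nM and compound 3 `O=C(Cc1csc2nc(-c3ccc(Br)cc3)cn12)N/N=C/c1ccc(O)cc1` at 10500 nM. Two measured steps show where the last of these stands: there is a 1.2-fold lower number from compound 1 to compound 3 (0.09 log units; within the scatter), and there is a 3.2-fold higher number from compound 2 to compound 3 (0.51 log units; beyond the scatter). Only compound 2 therefore stands apart, with the lowest number of the three.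

Compound 4 `COc1cccc(OC)c1/C=N/NC(=O)Cc1csc2nc(-c3ccc(Br)cc3)cn12` keeps the core and changes the ring: 2,6-dimethoxyphenyl in place of 4-hydroxyphenyl on a carbon with a double bond to nitrogen. In words, 2,6-dimethoxyphenyl takes the place of 4-hydroxyphenyl on a carbon with a double bond to nitrogen. Among the measured compounds shown here, no measured compound carries a methoxy group, so the only guide is the size of the ring changes seen so far. The largest of them, a 4.0-fold lower number from compound 1 to compound 2 (0.60 log units; beyond the scatter), is modest, so a large shift is not expected, and with no clear direction to follow, no step beyond the scatter is expected in this assay. The estimated change is a 1.3-fold lower number from compound 3 to compound 4 (0.12 log units; within the scatter). For compound 4 the expected value is 8000 nM, with an estimated range from 2500 nM to 25000 nM.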

Compound 4, concentration for 50% growth inhibition: 16200 nM
For compound 4 the middle estimate is 2.0-fold (0.31 log units) below the measured one; the measured number falls inside the stated range.
By their numbers in this assay, from the lowest: compound 2; then compounds 3, 1 and 4 (each within the scatter of the next).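

In this assay, the 2,6-dimethoxyphenyl ring does not separate from the plain phenyl or 4-hydroxyphenyl rings: there is a 1.3-fold higher number from compound 1 to compound 4 (0.10 log units; within the scatter) and a 1.5-fold higher number from compound 3 to compound 4 (0.19 log units; within the scatter). Against the 2-hydroxyphenyl ring, there is a 5.0-fold higher number from compound 2 to compound 4 (0.70 log units; beyond the scatter), so compound 2 remains apart from all three other compounds, and carrying oxygen-bearing groups on this ring does not by itself match compound 2, as compound 3 and compound 4 both show. No measurement shown here explains why this ring change gives these results.

Going by these compounds, it remains open whether a ring carrying a single methoxy group would stay close to compound 2 or join the other three, so the effect of replacing a hydroxy group with a methoxy group cannot yet be separated from the effect of having two methoxy groups on the ring. Also open, on these data alone, is how an amine or a carboxylic acid on this ring would read, and whether the standing of compound 2 would hold if the shared core were changed.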